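Swapping the amide ring: from oxazole to chloropyridine

The source may hold more compounds than are shown below. What is called first, only, known or untested is meant among the compounds shown, and "the series" means these compounds.

Of the compounds shown here, three sharing one core have been tested in a functional assay on A549 cells (Homo sapiens) for antiproliferative activity, read by MTT assay, with a stated time of 72 h; on this read-out higher numbers stand for weaker inhibition and lower numbers for stronger inhibition. Compound 1 `CS(=O)(=O)c1ccc(C(=O)Nc2ccc(Cl)c(-c3nnc4c(Cl)cccn34)c2)c(Cl)c1` gives > 100000 nM, which is a limit of the assay rather than a number. Compound 3 `O=C(Nc1ccc(Cl)c(-c2nnc3c(Cl)cccn23)c1)c1ccc(C(F)(F)F)cc1Cl` likewise gives > 100000 nM, again a limit. The change from compound 1 to compound 3 is a step that the two limits leave unreadable from compound 1 to compound 3, so it cannot be sized. Among the measured compounds shown here, compound 2 `O=C(Nc1ccc(Cl)c(-c2nnc3c(Cl)cccn23)c1)c1ccon1` is the only one with a number, giving 42700 nM. Compound 4 `O=C(Nc1ccc(Cl)c(-c2nnc3c(Cl)cccn23)c1)c1cccnc1Cl` differs from compound 2 by 2-chloropyridin-3-yl in place of 1,2-oxazol-3-yl on a carbonyl carbon. For the measured compounds named here, no measured step matches this change; the only guide is the limit of > 100000 nM in this assay, at which 2 of the 3 values shown sit, where both compounds bearing a six-membered aromatic ring with a chlorine on the carbonyl carbon sit. Compound 4 is therefore expected to lose some activity, a 1.9-fold higher number from compound 2 to compound 4 (0.27 log units; within the scatter), and to give about 80000 nM, plausibly between 30000 nM and 200000 nM.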

Compound 4, half-maximal inhibitory concentration: 35800 nM
Compound 4: middle estimate off by 2.2-fold (0.35 log units), on the high side; measured number inside the range.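

Replacing 1,2-oxazol-3-yl with 2-chloropyridin-3-yl on the carbonyl carbon gives a 1.2-fold lower number from compound 2 to compound 4 (0.08 log units; within the scatter), so compound 2 and compound 4 cannot be told apart. This position therefore accepts either a five-membered or a six-membered aromatic ring without a readable difference. A six-membered aromatic ring carrying a chlorine on this carbonyl carbon does not by itself place a compound at the limit: the limit of > 100000 nM in this assay, at which 2 of the 4 values shown sit.

As far as these compounds go, what separates compound 4 from compound 1 and compound 3 remains open. So does whether a ring bearing an amine or a carboxylic acid here would differ from compound 2 and compound 4.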